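A few compounds are considered here, and "the series" means these few. Any claim that something is new, unique, unknown or untested is made for them only; others in the source may bear on it.

Of the compounds shown here, two have been measured in an ADME assay on microsomes from liver (Homo sapiens), read by LC-MS, using NADPH, with a stated time of 30 min, tested at 1 uM; on this read-out higher numbers stand for a more stable compound and lower numbers for a less stable compound. Compound 1 `Cc1nc(N)nc(N[C@@H](C)c2cc3ccc(F)cn3c(=O)c2-c2ccccc2)c1C#N` gives 83%. Compound 2 `Cc1c([C@H](C)Nc2nc(N)nc(N)c2C#N)c(-c2ccccc2)c(=O)n2cc(F)ccc12` gives 80%. Compound 2 therefore stands alongside compound 1: the gap between the two numbers lies within the usual scatter of the method, so neither can be called more or less stable than the other, and both show a large share of material surviving the incubation.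

Compound 3 `Cc1nc(N)nc(N[C@@H](C)c2c(-c3ccccc3)c(=O)n3cc(F)ccc3c2C)c1C#N` differs from compound 2 in one place, (methyl in place of amino on an aromatic carbon), that is, methyl in place of amino on an aromatic carbon. Within the data shown here, no pair of measured compounds shows this same change, so there is no measured step to lean on. Because compound 2 gives 80%, compound 3 is expected to remain near that level, with an expected step of a number 5 percentage points lower from compound 2 to compound 3 (within the scatter) that should stay within the scatter or only slightly beyond it, downward if anything. The estimate for compound 3 is 75%, with a range from 55% to 92%.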

Compound 3, percent of the compound remaining: 96%
The estimate for compound 3 lay 21 percentage points below the measured number, and the stated range ends below it.
By their numbers in this assay, from the lowest: compounds 2 and 1 (each within the scatter of the next); then compound 3.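

In this assay, an amino group on an aromatic carbon next to the ring nitrogen and ortho to a cyano group gives way to methyl, and this single change brings a number 16 percentage points higher from compound 2 to compound 3 (beyond the scatter) as the ring substituent changes from 2,6-diamino-5-cyanopyrimidin-4-yl to 2-amino-5-cyano-6-methylpyrimidin-4-yl. Among these compounds, a second single change, one added methyl group on the core, brings a number 13 percentage points higher from compound 1 to compound 3 (beyond the scatter) so that compound 3, the only compound here carrying both methyl groups, stands clear of the other two. Nothing measured here explains either step.

As far as these compounds go, whether an ethyl or methoxy group on the same carbon would match methyl remains open. So does whether either step would keep its size on a different core.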